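Alkynyl end group in the nitrile series: compound 2 to compound 3

A few compounds are considered here, and "the series" means these few. Any claim that something is new, unique, unknown or untested is made for them only; others in the source may bear on it.

Compound 1 `Cn1cncc1C(OCc1ccc(C#N)cc1-c1ccccc1)c1ccc(C#N)cc1`: 140 nM
Compound 2 `Cn1cncc1C(OCc1ccc(C#N)cc1C#Cc1ccc([N+](=O)[O-])cc1)c1ccc(C#N)cc1`: 36 nM

In a functional assay on NIH3T3 cells (Mus musculus) (on this read-out lower numbers stand for an effect already at smaller amounts and higher numbers for an effect only at larger amounts of compound), compound 2 holds the lower of the two numbers, at 36 nM. Compound 3 `Cn1cncc1C(OCc1ccc(C#N)cc1C#CC(C)(C)C)c1ccc(C#N)cc1`, not yet measured, has tert-butyl in place of 4-nitrophenyl on a triple-bonded carbon. Going by the values given here, the one measured step bearing on this is a 3.9-fold lower number from compound 1 to compound 2 (0.59 log units; beyond the scatter), with 2-(4-nitrophenyl)ethynyl in place of phenyl on an aromatic carbon. That step was modest, and it changed the ethynyl link and the 4-nitrophenyl end together. Among the compounds with values here, no measured compound separates the two, so the evidence is thin. Compound 3 keeps the triple-bonded carbon but has no ring at the end, so a small step to a higher number is expected in this assay, smaller than the measured one, and a result within the scatter would not be surprising. The estimated change is a 2.2-fold higher number from compound 2 to compound 3 (0.35 log units; beyond the scatter). For compound 3 the expected value is 80 nM, with an estimated range of 20 nM to 300 nM.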

Compound 3, half-maximal effective concentration: 76.9 nM
For compound 3 the middle estimate is 1.0-fold (0.02 log units) above the measured one; the range from low to high includes it.
By their numbers in this assay, from the lowest: compound 2; then compounds 3 and 1 (each within the scatter of the next).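

With the triple-bonded carbon kept in both compounds, this pair isolates the end group, which the earlier step changed together with the ethynyl link. In this assay, tert-butyl in place of 4-nitrophenyl gives a 2.1-fold higher number from compound 2 to compound 3 (0.33 log units; beyond the scatter), so the end group alone has a modest but readable effect at this position, and the lower number of the series goes with the 4-nitrophenyl end. The comparison with the phenyl compound gives a 1.8-fold lower number from compound 1 to compound 3 (0.26 log units; within the scatter), so 3,3-dimethylbut-1-yn-1-yl and phenyl on the aromatic carbon cannot be told apart on this read-out, and an alkynyl group with a tert-butyl end does not by itself separate from the phenyl compound. No accompanying data speak to why the end group matters here.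

The compounds shown leave open how much of the 4-nitrophenyl result belongs to the nitro group and how much to the ring, a question that a plain phenyl on the triple-bonded carbon would address. Going by these compounds, it is also open how a longer alkyl chain, an amine or a carboxylic acid at the same place would compare with tert-butyl and 4-nitrophenyl.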